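The source may hold more compounds than are shown below. What is called first, only, known or untested is meant among the compounds shown, and "the series" means these compounds.

Measured compounds:
- compound 1 `COC1=C(C)C(=O)/C(=C(O)/C=C/c2ccc(OC)cc2)C(=O)C1(C)C`: 18.2 ug/mL
- compound 2 `COC1=C(C)C(=O)/C(=C(O)/C=C/c2cccc(OC)c2)C(=O)C1(C)C`: 14.3 ug/mL
- compound 3 `COC1=C(C)C(=O)/C(=C(O)/C=C/c2ccccc2C)C(=O)C1(C)C`: 9 ug/mL

These three compounds share one core and differ only in the aryl group at the end of the chain. In a functional assay on PC-3 cells (Homo sapiens) for cytotoxicity (a lower number here means that less compound is needed, a higher number that more compound is needed for the effect), compound 2 gives 14.3 ug/mL, the second highest of the three numbers; its steps to the other two, a 1.3-fold lower number from compound 1 to compound 2 (0.10 log units; within the scatter) and a 1.6-fold lower number from compound 2 to compound 3 (0.20 log units; within the scatter), both stay within the scatter, so no order among them can be claimed. Among the compounds with values here, the one step that reaches beyond the scatter is a 2.0-fold lower number from compound 1 to compound 3 (0.31 log units; beyond the scatter), a modest one.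

Compound 4 `C=Cc1ccccc1/C=C/C(O)=C1/C(=O)C(C)=C(OC)C(C)(C)C1=O` has not been measured yet. It differs from compound 2 as follows: 2-vinylphenyl in place of 3-methoxyphenyl on a double-bonded chain carbon bound to a double-bonded chain carbon. The step that bears most on it is the replacement that gave compound 3, where a group on the same ring position entered and the number fell: a 2.0-fold lower number from compound 1 to compound 3 (0.31 log units; beyond the scatter) and a 1.6-fold lower number from compound 2 to compound 3 (0.20 log units; within the scatter). A 2-vinylphenyl is a new group, so its effect is not directly known, but by analogy a modest step toward a lower number is expected, a 1.4-fold lower number from compound 2 to compound 4 (0.16 log units; within the scatter). Compound 4 is therefore estimated at 10 ug/mL in this assay, with a range from 5 ug/mL to 20 ug/mL.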

Compound 4, concentration for half-maximal effect: 4.6 ug/mL
For compound 4 the middle estimate is 2.2-fold (0.34 log units) above the measured one; the whole stated range lies above it.
By their numbers in this assay, from the lowest: compounds 4, 3, 2 and 1 (each within the scatter of the next, the first and the last beyond it).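

Within the data shown here, the step of a 3.1-fold lower number from compound 2 to compound 4 (0.49 log units; beyond the scatter) is the first from compound 2 that reaches beyond the scatter, and with a 4.0-fold lower number from compound 1 to compound 4 (0.60 log units; beyond the scatter) it sets the 2-vinylphenyl compound apart from both methoxyphenyl compounds in this assay in the same direction. Vinyl in place of methyl gives a 2.0-fold lower number from compound 3 to compound 4 (0.29 log units; within the scatter) and so compound 3 and compound 4 cannot be ordered, which means the 2-vinylphenyl cannot be told apart from the 2-methylphenyl here. Nothing available explains why the number falls with this group.

The compounds shown leave open whether 2-ethylphenyl or 2-methoxyphenyl would give numbers like those of compound 3 and compound 4. They also leave open how a phenyl ring carrying an amine or a carboxylic acid would read in this assay.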